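Removing a methyl from the core of compound 3

The compounds below may be only part of what the source reports. "The series", "measured", "known", "first", "only" and "open" are said of these compounds alone.

Compound 1 `COc1cc2c(/C=C3/C(=O)Nc4ccc(O)cc43)c(Cl)n(Cc3cc(OC)c(OC)c(OC)c3)c2cc1C`: 1410 nM
Compound 2 `COc1cc2c(/C=C3/C(=O)Nc4ccc(Cl)cc43)c(Cl)n(Cc3cc(OC)c(OC)c(OC)c3)c2cc1C`: 1860 nM
Compound 3 `COc1cc2c(cc1C)NC(=O)/C2=C/c1c(Cl)n(Cc2cc(OC)c(OC)c(OC)c2)c2cc(C)c(OC)cc12`: 3240 nM

In a functional assay on cells (Leukemia cell, Homo sapiens) for cytotoxicity, with a stated time of 48 h (a lower number here means a stronger inhibitor of growth, a higher number a weaker inhibitor of growth), compound 3 gives the highest of the three numbers; its gap to compound 2 lies within the scatter, and only its gap to compound 1 lies beyond it. For the measured compounds named here, the one single-point step measured so far, a 1.3-fold higher number from compound 1 to compound 2 (0.12 log units; within the scatter), changes a different part of the shared core and does not bear on the change considered here. Compound 4 `COc1ccc2c(c1)/C(=C\c1c(Cl)n(Cc3cc(OC)c(OC)c(OC)c3)c3cc(C)c(OC)cc13)C(=O)N2` differs from compound 3 by hydrogen in place of methyl on an aromatic carbon. Going by the values given here, with no measured step touching this position, no shift beyond the scatter is expected, so compound 4 is estimated at 3000 nM (range 1200 nM to 7500 nM), which corresponds to an expected step of a 1.1-fold lower number from compound 3 to compound 4 (0.03 log units; within the scatter).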

Compound 4, concentration for 50% growth inhibition: 6170 nM
For compound 4 the middle estimate is 2.1-fold (0.31 log units) below the measured one; the measured number falls inside the stated range.
By their numbers in this assay, from the lowest: compounds 1, 2, 3 and 4 (each within the scatter of the next, the first and the last beyond it).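

In this assay, hydrogen in place of methyl on the aromatic carbon ortho to a methoxy group gives a 1.9-fold higher number from compound 3 to compound 4 (0.28 log units; within the scatter) and so does not show that this methyl matters. Larger steps appear at a different place on the shared core, where methoxy in place of chloro gives a 3.3-fold higher number from compound 2 to compound 4 (0.52 log units; beyond the scatter) and methyl in place of hydrogen on the oxygen gives a 4.4-fold higher number from compound 1 to compound 4 (0.64 log units; beyond the scatter) as well. Nothing available explains these steps. From the compounds shown here alone, whether an ethyl group, an amine or a carboxylic acid on that aromatic carbon would shift the number beyond the scatter remains open.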